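Replacing piperidinyl with methylpiperazinyl on the chain carbon

The source may hold more compounds than are shown below. What is called first, only, known or untested is meant among the compounds shown, and "the series" means these compounds.

Three compounds share one core and differ only in the amine on a saturated chain carbon bound to an aromatic carbon. In a functional assay on HCT-116 cells (Homo sapiens) for cytotoxicity, read by MTT assay, with a stated time of 72 h (on this read-out higher numbers stand for weaker inhibition and lower numbers for stronger inhibition), compound 1 `CCN(CC)Cc1ccc(-c2ccnc3ccc(-c4cnc(OC)c(NS(=O)(=O)c5ccc(F)cc5F)c4)cc23)cc1` gives 5 nM, compound 2 `COc1ncc(-c2ccc3nccc(-c4ccc(CN5CCCC5)cc4)c3c2)cc1NS(=O)(=O)c1ccc(F)cc1F` gives 18.8 nM, and compound 3 `COc1ncc(-c2ccc3nccc(-c4ccc(CN5CCCCC5)cc4)c3c2)cc1NS(=O)(=O)c1ccc(F)cc1F` gives 34.1 nM, the highest of the three. The steps were a 3.8-fold higher number from compound 1 to compound 2 (0.58 log units; beyond the scatter), a 6.8-fold higher number from compound 1 to compound 3 (0.83 log units; beyond the scatter) and a 1.8-fold higher number from compound 2 to compound 3 (0.26 log units; within the scatter). Compound 4 `COc1ncc(-c2ccc3nccc(-c4ccc(CN5CCN(C)CC5)cc4)c3c2)cc1NS(=O)(=O)c1ccc(F)cc1F` carries 4-methylpiperazin-1-yl in place of piperidin-1-yl on a saturated chain carbon bound to an aromatic carbon. Among the compounds with values here, no measured step shows this change; the closest, from compound 2 to compound 3, altered a saturated ring without leaving the scatter, so compound 4 is expected near compound 3, with a 1.2-fold higher number from compound 3 to compound 4 (0.07 log units; within the scatter) in this assay. The estimate for compound 4 is 40 nM, ranging from 14 nM to 115 nM.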

Compound 4, half-maximal inhibitory concentration: 43.9 nM
Beside the measured number, compound 4's estimate is 1.1-fold (0.04 log units) below it, and the stated range covers the measured number.
By their numbers in this assay, from the lowest: compound 1; then compounds 2, 3 and 4 (each within the scatter of the next, the first and the last beyond it).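

Swapping piperidin-1-yl for 4-methylpiperazin-1-yl on this chain carbon makes no clear difference in this assay, with a 1.3-fold higher number from compound 3 to compound 4 (0.11 log units; within the scatter), so the added ring nitrogen and its methyl are tolerated here. Unlike piperidin-1-yl, the new group does stand apart from pyrrolidin-1-yl, with a 2.3-fold higher number from compound 2 to compound 4 (0.37 log units; beyond the scatter). Diethylamino keeps the lowest number, with an 8.8-fold higher number from compound 1 to compound 4 (0.94 log units; beyond the scatter).

Nothing measured here gives a cause for these steps. As far as these compounds go, whether an open-chain amine such as dimethylamino or a morpholin-4-yl ring would match compound 1 remains open.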